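The source may hold more compounds than are shown below. What is called first, only, known or untested is meant among the compounds shown, and "the series" means these compounds.

Of the compounds shown here, three share one core and have been measured in a functional assay on SAOS-2 cells (Homo sapiens) for antiproliferative activity, read by MTT assay, with a stated time of 72 h; on this read-out lower numbers stand for stronger inhibition and higher numbers for weaker inhibition. Compound 1 `CCCCOC1=C(C(=O)c2ccccc2)C(c2ccc(Br)cc2)N(CCCn2ccnc2)C1=O` gives 11600 nM, the lowest number of the three. Compound 2 `NC1=C(C(=O)c2ccccc2)C(c2ccc(Br)cc2)N(CCCn2ccnc2)C1=O` gives 107000 nM, and compound 3 `O=C(C1=C(Nc2ccc(Br)cc2)C(=O)N(CCCn2ccnc2)C1c1ccc(Br)cc1)c1ccccc1` gives 23800 nM. Against these, compound 1 stands at the strong end: its nearest neighbour is compound 3, its furthest is compound 2.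

Compound 4 `O=C(C1=C(NCc2ccccc2)C(=O)N(CCCn2ccnc2)C1c1ccc(Br)cc1)c1ccccc1` is the one still to be measured. It differs from compound 1 in a single place: benzylamino in place of butoxy on a double-bonded ring carbon.

Among the measured compounds shown here, two measured steps touch the same position. Swapping butoxy for a bare amino gave a 9.2-fold higher number from compound 1 to compound 2 (0.96 log units; beyond the scatter), while swapping it for (4-bromophenyl)amino gave a 2.1-fold higher number from compound 1 to compound 3 (0.31 log units; beyond the scatter). Putting a 4-bromophenyl onto that amine nitrogen gave a 4.5-fold lower number from compound 2 to compound 3 (0.65 log units; beyond the scatter), so an amine carrying an aromatic ring sits closer to compound 1 than the unsubstituted amine does. Benzylamino is also an amine that carries an aromatic ring, so the expected outcome for this assay is a modest rise in the number, near what compound 3 shows, rather than the larger rise seen for compound 2.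

The estimated step is a 1.9-fold higher number from compound 1 to compound 4 (0.28 log units; within the scatter), giving compound 4 an expected value of 22000 nM, with a likely range from 8000 nM to 60000 nM.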

Compound 4, half-maximal inhibitory concentration: 31600 nM
Compound 4: middle estimate off by 1.4-fold (0.16 log units), on the low side, within the range that was stated.
By their numbers in this assay, from the lowest: compound 1; then compounds 3 and 4 (each within the scatter of the next); then compound 2.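

This result shows that the lower number seen with compound 3 does not depend on a 4-bromophenyl group on the amine nitrogen. In this assay, benzyl on that nitrogen gives a 3.4-fold lower number from compound 2 to compound 4 (0.53 log units; beyond the scatter) and so also sets the number well apart from that of the bare amine, while exchanging the two nitrogen substituents gives a 1.3-fold higher number from compound 3 to compound 4 (0.12 log units; within the scatter) and leaves them unresolved from each other. Even so, benzylamino does not match butoxy, with a 2.7-fold higher number from compound 1 to compound 4 (0.44 log units; beyond the scatter) as the step, so all three amine-linked groups at this double-bonded ring carbon give higher numbers than butoxy, and no compound here goes against that pattern.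

Compound 1 differs from the others in both the oxygen link and its open butyl chain, so these compounds cannot show which of the two goes with its lower number, and butylamino and benzyloxy groups at this carbon would separate the two. The data shown also offer no measured explanation for any of these differences.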